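The source may report more compounds than this note shows. Statements on the series, on what has been measured and on what is new or still open speak of the compounds shown alone.

Compound 1 `COc1cc(/C=C/C(=O)c2ccc(OCCn3cc(CN4C(=O)/C=C/C(C)(C)C/C=C(\C)CC/C=C/4C)nn3)cc2O)cc(OC)c1OC` and compound 2 `C/C1=C\CC(C)(C)/C=C/C(=O)N(Cc2cn(CCOc3ccc(C(=O)/C=C/c4ccc(C)cc4)c(O)c3)nn2)/C(C)=C/CC1` share a core and differ only in one ring: 4-methylphenyl in place of 3,4,5-trimethoxyphenyl on a double-bonded chain carbon bound to a double-bonded chain carbon. In a functional assay on SW480 cells (Homo sapiens) for antiproliferative activity (a lower number here means a stronger inhibitor, a higher number a weaker inhibitor), compound 1 gives 2.61 ug/mL, while compound 2 gives 1.16 ug/mL, so the change gave a 2.3-fold lower number from compound 1 to compound 2 (0.35 log units; beyond the scatter). Compound 3 `COc1cc(/C=C/C(=O)c2ccc(OCCCN3C(=O)/C=C/C(C)(C)C/C=C(\C)CC/C=C/3C)cc2)cc(OC)c1OC` is built on a different core; how its core differs from that of compound 1 is not broken down here. In this assay compound 3 gives 0.71 ug/mL. Compound 4 `C/C1=C\CC(C)(C)/C=C/C(=O)N(CCCOc2ccc(C(=O)/C=C/c3ccc(C)cc3)cc2)/C(C)=C/CC1` has not yet been measured; it carries the same change relative to compound 3: 4-methylphenyl in place of 3,4,5-trimethoxyphenyl on a double-bonded chain carbon bound to a double-bonded chain carbon. Because the step of a 2.3-fold lower number from compound 1 to compound 2 (0.35 log units; beyond the scatter) was modest, the step from compound 3 to compound 4 is expected to be a 2.0-fold lower number from compound 3 to compound 4 (0.31 log units; beyond the scatter). Compound 4 is therefore estimated to give 0.35 ug/mL in this assay, somewhere between 0.15 ug/mL and 0.8 ug/mL.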

Compound 4, half-maximal inhibitory concentration: 1.57 ug/mL
Estimate against measurement, compound 4: 4.5-fold (0.65 log units) below, and the stated range ends below it.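

In this assay, putting 4-methylphenyl in place of 3,4,5-trimethoxyphenyl gave a 2.2-fold higher number from compound 3 to compound 4 (0.34 log units; beyond the scatter), so a swap that strengthened the inhibitor on the core of compound 1 weakened it on the core of compound 3. The change therefore does not carry over from one core to the other, since the two steps run in opposite directions: the same change on two cores in this assay, a 2.3-fold lower number (0.35 log units; beyond the scatter) from compound 1 to compound 2 and a 2.2-fold higher number (0.34 log units; beyond the scatter) from compound 3 to compound 4, 5.0-fold (0.70 log units) apart, beyond the scatter of two such steps. This does not show which feature of the two cores reverses the step, and two cores alone give no rule for the wider series.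

From the compounds shown here alone, it remains open how either core would respond if the ring carried an amine or a carboxylic acid instead, and whether the reversal would persist with a longer chain.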